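The source may report more compounds than this note shows. Statements on the series, on what has been measured and on what is new or still open speak of the compounds shown alone.

Going by the values given here, compound 2 `C=C1C[C@]23C[C@@]1(O)CC[C@@H]2c1cccc(C)c1[C@@H]3Cn1cc(-c2ccccc2)nn1` and compound 1 `Cc1c(O)ccc2c1[C@H](Cn1cc(-c3ccc(F)cc3)nn1)[C@@]13CC(=O)[C@@](C)(CC[C@@H]21)C3` are the two measured members of this set, each carrying a different aryl group on the triazole. In a functional assay on A549 cells (Homo sapiens) for cytotoxicity, read by MTT assay, with a stated time of 4 days (a higher number here means a weaker inhibitor, a lower number a stronger inhibitor), compound 2 gives only a limit, > 20000 nM. Compound 1 likewise reaches only a limit in this assay, > 20000 nM. Compound 2 thus stands nowhere within the measurable range, since (the limit of > 20000 nM in this assay, at which 2 of the 2 values shown sit). Compound 3 `C=C1C[C@]23C[C@@]1(O)CC[C@@H]2c1cccc(C)c1[C@@H]3Cn1cc(-c2ccccn2)nn1` has not been measured; it differs from compound 2 by pyridin-2-yl in place of phenyl on an aromatic carbon. Among the compounds with values here, no measured step between compounds is available, and with both known values at the limit no direction can be read from them. The step from compound 2 to compound 3 is expected to be none beyond the scatter, with compound 3 estimated to stay near the limit, a number no higher from compound 2 to compound 3 (the limit leaves the size open). Compound 3 is expected to give about 20000 nM in this assay, within a range from 5000 nM to 60000 nM.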

Compound 3, half-maximal inhibitory concentration: > 20000 nM
Compound 3 ended at the assay's limit (the forecaster's own chance of this, stated with the estimate: 75%); the middle value lies on the limit itself.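

No step can be read from compound 2 to compound 3, since both stand at a limit of the assay rather than at a number: the limit of > 20000 nM in this assay, at which 3 of the 3 values shown sit.

The compounds shown leave open whether any aryl group on the triazole gives a value within the measurable range of this assay at all.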